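The source may hold more compounds than are shown below. What is called first, only, known or untested is meant among the compounds shown, and "the series" means these compounds.

Compound 1 `O=C(Nc1ccc2c(c1)B(O)OC2)c1ccccc1`: > 100000 nM
Compound 2 `O=C(Nc1ccc2c(c1)B(O)OC2)c1ccccc1Cl`: > 100000 nM
Compound 3 `O=C(Nc1ccc2c(c1)B(O)OC2)c1ccccc1-c1ccccc1`: > 100000 nM

All three readings come from a functional assay on PBMC cells (Homo sapiens) for inhibition, read by HTRF, with stated times of 15 min and 24 h; on this read-out lower numbers stand for stronger inhibition and higher numbers for weaker inhibition. Compound 1 is known only as a limit, > 100000 nM, and has no numerical value. For the measured compounds named here, the other two compounds offer no number either, and the series so far rests on (the limit of > 100000 nM in this assay, at which 3 of the 3 values shown sit).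

Compound 4 `O=C(Nc1ccc2c(c1)B(O)OC2)c1cccc(C(F)(F)F)c1` differs from compound 1 as follows: trifluoromethyl in place of hydrogen on an aromatic carbon. In words, this is trifluoromethyl in place of hydrogen on an aromatic carbon, meta to a large group.

The nearest measured changes are a step that the two limits leave unreadable from compound 1 to compound 2 and a step that the two limits leave unreadable from compound 1 to compound 3, and a step that the two limits leave unreadable from compound 2 to compound 3 also bears on the series. None of these steps has a readable size. On the basis of a step that the two limits leave unreadable from compound 1 to compound 3, no clear gain in this assay is expected, and another limit is the likeliest report. The expected step is a number no higher from compound 1 to compound 4 (the limit leaves the size open), and no direction can be claimed for it. For compound 4 the estimated value is 100000 nM, with an expected range of 40000 nM to 200000 nM.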

Compound 4, half-maximal inhibitory concentration: > 10000 nM
Compound 4: no number, only a limit; the forecaster's own chance of this, stated with the estimate: 85%; the middle value does not contradict the limit.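

In this assay compound 4 is known only as a limit, > 10000 nM, and compound 1 also has no number, so no new step can be read between them. The compounds shown leave open whether chloro, phenyl or trifluoromethyl gives any measurable inhibition, and how these groups rank.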